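A fluorobenzyl amine replaces the benzamidoethyl chain

A few compounds are considered here, and "the series" means these few. Any claim that something is new, unique, unknown or untested is made for them only; others in the source may bear on it.

Compound 3 `O=C(NCCCNc1c(C(=O)NCc2ccc(F)cc2)nc(Br)c2cccnc12)c1ccccc1` carries a 2-benzamidoethyl chain on the amine nitrogen of the shared core. In a functional assay on HCT-116 cells (Homo sapiens) for cytotoxicity, read by MTT assay, with a stated time of 72 h (on this read-out higher numbers stand for weaker inhibition and lower numbers for stronger inhibition), compound 3 gives only a limit of the assay, > 10000 nM. Its nearest relative, compound 2 `CNCCCNc1c(C(=O)NCc2ccc(F)cc2)nc(Br)c2cccnc12`, differs by having methyl where compound 3 has benzoyl on that amine nitrogen. In this assay compound 2 likewise reaches only a limit, > 10000 nM. The step that the two limits leave unreadable from compound 2 to compound 3 is therefore not readable, and the pattern is summed up by the limit of > 10000 nM in this assay, at which 2 of the 3 values shown sit. Compound 1 `O=C(NCc1ccc(F)cc1)c1nc(NCCO)c2cccnc2c1O`, the hydroxy analogue, has "not determined" (no result reported) in this assay, so it adds nothing to the comparison.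

Compound 4 `O=C(NCc1ccc(F)cc1)c1nc(Br)c2cccnc2c1NCc1ccc(F)cc1` is the next compound, related to compound 3 by 4-fluorophenyl in place of 2-benzamidoethyl on a saturated chain carbon bound to a nitrogen on an aromatic ring. Among the compounds with values here, no measured step bears on this change, since the one recorded step is unreadable and both neighbours sit at the limit. The account therefore expects compound 4 to sit at the same limit, and its estimated value in this assay is 12000 nM, between 4000 nM and 40000 nM. That estimate means a step that the limit leaves unreadable from compound 3 to compound 4 is expected, which is no change beyond the scatter.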

Compound 4, half-maximal inhibitory concentration: > 20000 nM
Compound 4 was reported as a limit; the forecaster's own chance of this, stated with the estimate: 70%; middle value at least 1.6-fold (0.22 log units) away from the limit.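

In this assay compound 4 reaches only a limit, > 20000 nM. Within the data shown here, compound 2 and compound 3 also stand at limits, so no step from either to compound 4 can be read. The compounds shown leave open whether any change on the shared core gives a measurable value in this assay.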